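The source may hold more compounds than are shown below. What is called first, only, known or untested is meant among the compounds shown, and "the series" means these compounds.

Compound 1, `CCC(=O)c1c(C)nn(CCCN2CCN(c3ccc(C)cc3)CC2)c(=O)c1N`, gives 40%.
Compound 2, `CCCCC(=O)c1c(C)nn(CCCN2CCN(c3ccc(C)cc3)CC2)c(=O)c1N`, gives 23%.

These two numbers come from a functional assay on the whole organism (Abdomen, strain Swiss) for inhibition, with Mus musculus as the target, with stated times of 30 min, 10 min and 5 min, at a dose of 20 mg/kg by the oral route; on this read-out lower numbers stand for a weaker effect and higher numbers for a stronger effect at the one dose given. On that read-out compound 2 stands lowest of the two, with compound 1 the nearest and higher. Going by the values given here, the one step between them, a number 17 percentage points lower from compound 1 to compound 2 (beyond the scatter), is the only measured change in the whole set.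

Compound 3, `C/C=C/c1c(C)nn(CCCN2CCN(c3ccc(C)cc3)CC2)c(=O)c1N`, has not yet been measured. It differs from compound 2 in one place: prop-1-en-1-yl in place of butylcarbonyl on an aromatic carbon. The chain on that aromatic carbon becomes shorter and loses its carbonyl.

The measured step bears on this only loosely. Going from compound 1 to compound 2 made the chain longer and lowered the read-out in this assay; the move to compound 3 goes the other way in chain length, but no measured pair shows what removing the carbonyl does. With that, a modest rise is expected, so the step from compound 2 to compound 3 in this assay is estimated at a number 12 percentage points higher from compound 2 to compound 3 (beyond the scatter). Compound 3 is expected to give about 35%, within 15% to 55%.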

Compound 3, a percentage reported as inhibition, in the whole organism at one dose (the size of the read-out at that dose, not a potency): 44%
Compound 3: middle estimate off by 9 percentage points, on the low side; the range from low to high includes it.
By their numbers in this assay, from the lowest: compound 2; then compounds 1 and 3 (each within the scatter of the next).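

In this assay, the aromatic carbon opposite the ring nitrogen turns out to tolerate a group without a carbonyl: prop-1-en-1-yl in place of butylcarbonyl gives a number 21 percentage points higher from compound 2 to compound 3 (beyond the scatter) and so shows that a carbonyl on this chain is not needed for an effect at this dose. Prop-1-en-1-yl in place of propanoyl gives a number 4 percentage points higher from compound 1 to compound 3 (within the scatter) and so leaves compound 1 and compound 3 indistinguishable here, even though only compound 1 carries a carbonyl at this position. No independent measurement is available to explain either change.

Compound 2 and compound 3 differ in both chain length and the presence of the carbonyl, so the compounds shown do not separate the contribution of each. Also open, on these data alone, is what a saturated propyl chain, an amine or a carboxylic acid on this aromatic carbon would give in this assay at this dose.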